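The compounds below may be only part of what the source reports. "The series", "measured", "known", "first", "only" and "open" are said of these compounds alone.

Measured in an assay on MCF7 cells for inhibition of Serine-protein kinase ATM (Homo sapiens), read by immunofluorescence, with a stated time of 1 h; on this read-out higher numbers stand for weaker inhibition and lower numbers for stronger inhibition:
compound 1 `COc1cc2ncnc(-n3nc(-c4ccccn4)nc3N)c2cc1[N+](=O)[O-]` gives 31100 nM
compound 2 `COc1cc2ncnc(-n3nc(-c4cccnc4)nc3N)c2cc1OC` gives 15000 nM
compound 3 `COc1cc2ncnc(-n3nc(-c4ccccc4)nc3N)c2cc1OC` gives 2000 nM

Compound 3 stands at the lowest number of the three in this assay; the nearest is compound 2, and the gap is a 7.5-fold lower number from compound 2 to compound 3 (0.88 log units; beyond the scatter). Compound 1 lies further off and differs from compound 2 in two places, so only its value is noted.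

Compound 4 `COc1cc2ncnc(-n3nc(C4CCCCC4)nc3N)c2cc1OC` differs from compound 3 by cyclohexyl in place of phenyl on an aromatic carbon. Within the data shown here, no measured step exchanges an aromatic ring for a non-aromatic one; the single one-place step, a 7.5-fold lower number from compound 2 to compound 3 (0.88 log units; beyond the scatter), changes only which aromatic ring is present and bears on the question loosely. A step toward higher numbers beyond the scatter is expected, a 4.0-fold higher number from compound 3 to compound 4 (0.60 log units; beyond the scatter). Compound 4 is estimated at 8000 nM, within 2000 nM to 40000 nM.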

Compound 4, half-maximal inhibitory concentration in the Serine-protein kinase ATM assay: > 40000 nM
Compound 4: a limit, no number (the forecaster's own chance of this, stated with the estimate: 15%); middle value at least 5.0-fold (0.69 log units) from the limit.
By their numbers in the Serine-protein kinase ATM assay, from the lowest: compound 3; then compound 2; then compound 1. At a limit, above all of these: compound 4.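

Cyclohexyl is the only non-aromatic ring shown on this aromatic carbon, and in the Serine-protein kinase ATM assay it falls behind both aromatic rings, with an at least 20-fold higher number from compound 3 to compound 4 (1.30 log units; beyond the scatter) and an at least 2.6-fold higher number from compound 2 to compound 4 (0.42 log units; beyond the scatter). Compound 4 reads > 40000 nM, a limit, so both steps are minimum sizes. The same exchange also moves a physicochemical assay for solubility, in phosphate buffer, with a stated time of 18 h, at pH 7.4 (a higher number here means a more soluble compound, a lower number a less soluble compound), where compound 3 gives 1000 nM and compound 4 gives 35000 nM as measured: the measured solubility of compound 3, 1000 nM, and of compound 4, 35000 nM, a 35-fold higher number (1.54 log units; beyond the scatter)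

From the compounds shown here alone, how far compound 4 lies past its limit stays open. So does what the Serine-protein kinase ATM assay gives at this carbon for a ring carrying an amine, such as piperidin-4-yl, or for a small chain such as methyl.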